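The compounds below may be only part of what the source reports. "The series", "measured", "known", "first", "only" and "open" are said of these compounds alone.

Compound 1 `O=c1ccc(-c2ccc3cn[nH]c3c2)cn1Cc1ccccc1C(F)(F)F`: 100 nM
Compound 2 `Nc1n[nH]c2cc(-c3ccc(=O)n(Cc4ccccc4F)c3)ccc12`: 4 nM
Compound 3 `O=C(N1CCOCC1)n1cc(-c2ccc3cn[nH]c3c2)ccc1=O`: > 2000 nM

Compound 3 stands at the weak end of these numbers: its result is a limit of the assay rather than a number, since (the limit of > 2000 nM in this assay, at which 1 of the 3 values shown sits). Compound 4 `O=c1ccc(-c2ccc3cn[nH]c3c2)cn1Cc1ccccc1` differs from it in one place: benzyl in place of (morpholin-4-yl)carbonyl on an aromatic nitrogen. Going by the values given here, no measured pair shows this exact change, so no measured step fixes its size. In an assay for inhibition of MAP kinase-interacting serine/threonine-protein kinase 2 (Homo sapiens), read by luminescence and ADP-Glo, with a stated time of 2 h (on this read-out lower numbers stand for stronger inhibition and higher numbers for weaker inhibition), a benzyl bearing a trifluoromethyl appears in compound 1, which gives 100 nM, and a benzyl bearing a fluorine appears in compound 2, which gives 4 nM. A large step toward stronger inhibition is therefore expected, an at least 10-fold lower number from compound 3 to compound 4 (1.00 log units; beyond the scatter). Compound 4 is estimated at 200 nM, within 50 nM to 800 nM.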

Compound 4, half-maximal inhibitory concentration: 75 nM
Beside the measured number, compound 4's estimate is 2.7-fold (0.43 log units) above it, within the range that was stated.
By their numbers in this assay, from the lowest: compound 2; then compounds 4 and 1 (each within the scatter of the next). At a limit, above all of these: compound 3.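

In this assay, benzyl in place of (morpholin-4-yl)carbonyl on the aromatic nitrogen gives an at least 26-fold lower number from compound 3 to compound 4 (1.42 log units; beyond the scatter), so this position on the shared core clearly tells these two groups apart. That step rests on a limit of the assay for compound 3: the limit of > 2000 nM in this assay, at which 1 of the 4 values shown sits. The trifluoromethyl on the benzyl makes no clear difference, as hydrogen in its place gives a 1.3-fold lower number from compound 1 to compound 4 (0.12 log units; within the scatter). The compounds shown leave open whether a methyl or a longer chain ending in an amine on this nitrogen would match benzyl, and how a carboxylic acid on the benzyl would behave.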